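Lengthening an ether chain on the best-tolerated compound

This account rests on a few compounds, and the source may have more. Where it says the series, first, only, none or still open, it means among the compounds named here.

Compound 2 `CC(=O)OC[C@H]1O[C@H](OC(C)C)C=CC1=O` gives 104000 nM in an ADME assay on Vero cells (Chlorocebus sabaeus) for cytotoxicity, read by resazurin assay, with a stated time of 24 h (a lower number here means that less compound is tolerated, a higher number that more compound is tolerated), the highest of the three numbers. Compound 1 `CC(C)CCO[C@@H]1C=CC(=O)[C@@H](COC(=O)C(C)(C)C)O1` gives 36000 nM and compound 3 `CC(C)O[C@@H]1C=CC(=O)[C@@H](COC(=O)C(C)(C)C)O1` gives 12500 nM, with an 8.3-fold lower number from compound 2 to compound 3 (0.92 log units; beyond the scatter) separating the ends of the series. Compound 4 `CC(=O)OC[C@H]1O[C@H](OCCC(C)C)C=CC1=O` differs from compound 2 by isopentyl in place of isopropyl on an oxygen on a saturated carbon. Within the data shown here, one measured step bears on this change, run in the opposite direction: a 2.9-fold lower number from compound 1 to compound 3 (0.46 log units; beyond the scatter), a step beyond the scatter, although compound 1 and compound 3 also differ from compound 2 at the carbonyl carbon. Reversing that step, a modest rise is expected for compound 4, estimated as a 2.1-fold higher number from compound 2 to compound 4 (0.33 log units; beyond the scatter). Compound 4 is therefore expected to give about 220000 nM in this assay, within a range of 90000 nM to 500000 nM.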

Compound 4, half-maximal cytotoxic concentration: 19800 nM
The estimate for compound 4 lay 11-fold (1.05 log units) above the measured number; measured number below the stated range.
By their numbers in this assay, from the lowest: compounds 3, 4 and 1 (each within the scatter of the next, the first and the last beyond it); then compound 2.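

On the core of compound 2, isopentyl in place of isopropyl brings a 5.3-fold lower number from compound 2 to compound 4 (0.72 log units; beyond the scatter), whereas the same swap raises the number on the core carrying tert-butyl, so the outcome of this change at the ether depends on the group on the carbonyl carbon: the same change on two cores in this assay, a 2.9-fold lower number (0.46 log units; beyond the scatter) from compound 1 to compound 3 and a 5.3-fold higher number (0.72 log units; beyond the scatter) from compound 4 to compound 2, 15-fold (1.18 log units) apart, beyond the scatter of two such steps. With isopentyl, methyl and tert-butyl on the carbonyl carbon cannot be told apart, a 1.8-fold lower number from compound 1 to compound 4 (0.26 log units; within the scatter), but with isopropyl they can: the same change on two cores in this assay, an 8.3-fold lower number (0.92 log units; beyond the scatter) from compound 2 to compound 3 and a 1.8-fold higher number (0.26 log units; within the scatter) from compound 4 to compound 1, 15-fold (1.18 log units) apart, beyond the scatter of two such steps.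

On these data alone, the four compounds cover only isopropyl and isopentyl, so how a straight butyl chain or a chain ending in an amine would behave on either core remains open.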